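The source may hold more compounds than are shown below. What is called first, only, known or untested is meant among the compounds shown, and "the series" means these compounds.

Measured so far:
- Compound 1 `C[C@@H](Oc1cc(C(=O)N(C)C)ccc1Nc1nc(O[C@H]2CC[C@@](C)(O)CC2)c2cc[nH]c2n1)C(F)(F)F`: 15600 ng.h/mL
- Compound 2 `COc1cc(C(=O)N(C)C)ccc1Nc1nc(O[C@H]2CCOC(C)(C)C2)c2cc[nH]c2n1`: 13200 ng.h/mL

In an ADME assay on the whole organism (Rattus norvegicus) for pharmacokinetics, at a dose of 10 mg/kg by the oral route (a lower number here means less compound in the circulation, a higher number more compound in the circulation at the dose given), compound 1 gives 15600 ng.h/mL and compound 2 gives 13200 ng.h/mL, two numbers within the scatter of each other. Compound 3 `CN(C)C(=O)c1ccc(Nc2nc(O[C@H]3CC[C@@](C)(O)CC3)c3cc[nH]c3n2)c(OCC(F)(F)F)c1` departs from compound 1 at one place: hydrogen in place of methyl on a saturated chain carbon bound to an oxygen on an aromatic ring and a saturated chain carbon. This is hydrogen in place of methyl, turning 1-(trifluoromethyl)ethoxy into 2,2,2-trifluoroethoxy. For the measured compounds named here, no measured pair shows this change, so the size of the step remains a judgement. A modest fall, not far beyond the scatter, is expected, with the estimated step being a 1.7-fold lower number from compound 1 to compound 3 (0.24 log units; within the scatter). For compound 3 the estimated value is 9000 ng.h/mL, within a range of 3500 ng.h/mL to 20000 ng.h/mL.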

Compound 3, area under the concentration-time curve: 8170 ng.h/mL
For compound 3 the middle estimate is 1.1-fold (0.04 log units) above the measured one, and the stated range covers the measured number.
By their numbers in this assay, from the lowest: compounds 3, 2 and 1 (each within the scatter of the next).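

Hydrogen in place of methyl on this saturated chain carbon, turning 1-(trifluoromethyl)ethoxy into 2,2,2-trifluoroethoxy, gives a 1.9-fold lower number from compound 1 to compound 3 (0.28 log units; within the scatter) in this assay. This first single-place pair therefore shows that, in this one instance, the read-out does not separate the two groups beyond the scatter. Nothing at hand bears on why the pair behaves this way.

The compounds shown leave open whether a longer chain or an amine on this carbon would also stay within the scatter of compound 1. They also leave open whether plain ethoxy, lacking the trifluoromethyl, would do so.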